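Swapping pyridin-2-yl for pyridin-4-yl on the shared core

The source may report more compounds than this note shows. Statements on the series, on what has been measured and on what is new or still open speak of the compounds shown alone.

- Compound 1 `OCC1CCN(c2nccnc2OC2CN(c3ccc4ccccc4n3)C2)C1` gives 167000 nM
- Compound 2 `Cc1ccc(-c2nccnc2OC2CN(c3ccc4ccccc4n3)C2)cc1` gives < 1000 nM
- Compound 3 `c1ccc(-c2nccnc2OC2CN(c3ccc4ccccc4n3)C2)nc1` gives 349000 nM

These results come from a physicochemical assay for solubility, in phosphate buffer, at pH 7.4; on this read-out lower numbers stand for lower solubility and higher numbers for higher solubility. The entry for compound 2 is a limit and not a number. Compound 3 stands highest of the two true numbers at 349000 nM. Its nearest neighbour lies a modest step away, a 2.1-fold higher number from compound 1 to compound 3 (0.32 log units; beyond the scatter).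

Compound 4 `c1ccc2nc(N3CC(Oc4nccnc4-c4ccncc4)C3)ccc2c1` differs from compound 3 in one place: pyridin-4-yl in place of pyridin-2-yl on an aromatic carbon. In words, pyridin-4-yl takes the place of pyridin-2-yl on an aromatic carbon. Among the measured compounds shown here, no measured step swaps one pyridinyl group for another. The nearest evidence is the large step of an at least 340-fold higher number from compound 2 to compound 3 (2.54 log units; beyond the scatter), where pyridin-2-yl replaced 4-methylphenyl, and the modest step above. The counts on both sides of the new change are the same, so no shift beyond the scatter is expected, and the expected step is a 1.4-fold lower number from compound 3 to compound 4 (0.14 log units; within the scatter). The large step still argues for a wide range. For compound 4 the estimate is 250000 nM, with an expected range from 80000 nM to 600000 nM.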

Compound 4, solubility: 56000 nM
Compound 4: middle estimate off by 4.5-fold (0.65 log units), on the high side; the measured number lies below the stated range.
By their numbers in this assay, from the lowest: compound 4; then compound 1; then compound 3. At a limit, below all of these: compound 2.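

In this assay the two pyridinyl groups are not interchangeable at this position, although they have the same atoms joined differently: pyridin-4-yl in place of pyridin-2-yl gives a clear drop (a 6.2-fold lower number from compound 3 to compound 4 (0.79 log units; beyond the scatter)). Which pyridinyl group is present also decides how the compound compares with the 3-(hydroxymethyl)pyrrolidin-1-yl compound: compound 3 lies above it, while pyridin-4-yl falls below it (a 3.0-fold lower number from compound 1 to compound 4 (0.47 log units; beyond the scatter)). Even so, the gain over 4-methylphenyl remains large (an at least 56-fold higher number from compound 2 to compound 4 (1.74 log units; beyond the scatter)), and the starting entry of that step is a limit and not a number.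

Nothing measured here gives a cause for the gap between the two pyridinyl groups. Also open, as far as these compounds go, is where pyridin-3-yl, or a phenyl ring carrying a carboxylic acid, would land on this scale.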